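A Second Chloro on a Weak Growth Inhibitor

This account rests on a few compounds, and the source may have more. Where it says the series, first, only, none or still open, it means among the compounds named here.

Compound 1 `O=S(=O)(/C=C/c1ccccc1)Cc1ccc(Nc2ncnc3ccccc23)cc1`: > 100000 nM (a limit of the assay)
Compound 2 `O=S(=O)(/C=C/c1ccc(Cl)cc1)Cc1ccc(Nc2ncnc3ccccc23)cc1`: 43000 nM

Both compounds were tested in a functional assay on PC-3 cells (Homo sapiens); a lower number here means a stronger inhibitor of growth, a higher number a weaker inhibitor of growth. Compound 1 gives > 100000 nM, which is a limit and not a number. Within the data shown here, compound 2, at 43000 nM, holds the only true number so far, so there is no wider series to rank it against.

The next compound, compound 3 `O=S(=O)(/C=C/c1ccc(Cl)cc1Cl)Cc1ccc(Nc2ncnc3ccccc23)cc1`, carries one further change: chloro in place of hydrogen on an aromatic carbon. The new chloro replaces a hydrogen on an aromatic carbon, ortho to a large group and meta to the chloro group already there.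

Among the measured compounds shown here, only one measured step bears on this. It is an at least 2.3-fold lower number from compound 1 to compound 2 (0.36 log units; beyond the scatter), which is the same kind of swap made once before. One step is thin evidence, and a second chloro at a new place need not repeat it. Even so, a similar modest move toward a lower number in this assay is the best expectation, and no change beyond the scatter remains possible. The expected step is a 2.2-fold lower number from compound 2 to compound 3 (0.33 log units; beyond the scatter). For compound 3 the estimated value is 20000 nM, with an expected range from 6000 nM to 70000 nM.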

Compound 3, concentration for 50% growth inhibition: 19000 nM
For compound 3 the middle estimate is 1.1-fold (0.02 log units) above the measured one; low and high end bracket the measured number.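

In this assay, the new chloro gives a 2.3-fold lower number from compound 2 to compound 3 (0.35 log units; beyond the scatter), so a carbon ortho to a large group also accepts a chloro, and in compound 3 the number falls further with the first chloro already in place. Among these compounds, this is the first step with a true number at both ends, which makes it the first whose size can be read exactly rather than as a bound. Across both changes, 2,4-dichlorophenyl in place of phenyl gives an at least 5.2-fold lower number from compound 1 to compound 3 (0.72 log units; beyond the scatter), but the value of compound 1, > 100000 nM, is a limit of the assay and not a number, so the full size of that step stays unknown: the limit of > 100000 nM in this assay, at which 1 of the 3 values shown sits.

The compounds shown leave open whether the drop belongs to chloro itself or would also appear with a fluoro, a methyl or a methoxy group at the same place, and whether this chloro would have a similar effect on a ring without the first one. They also leave open how an amine or a carboxylic acid would fare on this ring in this assay.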